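The source may report more compounds than this note shows. Statements on the series, on what has been measured and on what is new or still open speak of the compounds shown alone.

Measured so far:
compound 1 `CCc1cnc(N2CCC(c3nc(COc4ccc(-n5cnnn5)cc4)cs3)CC2)nc1` – > 100000 nM
compound 2 `CCc1cnc(N2CCC(c3nc(COc4ccc(/C=C5\CC(=O)NC5=O)cc4F)cs3)CC2)nc1` – > 100000 nM

In an ADME assay on NIH3T3 cells (Mus musculus) for cytotoxicity (a lower number here means a stronger inhibitor, a higher number a weaker inhibitor), compound 1 reports only a limit, > 100000 nM. In this assay compound 2 likewise reports only a limit, > 100000 nM. Both values sit at the limit of > 100000 nM in this assay, at which 2 of the 2 values shown sit, so compound 2 stands with compound 1 at the edge of what the assay can report, with no number inside the range. Compound 3 `CCc1cnc(N2CCC(c3nc(COc4ccc(/C=C5\CC(=O)NC5=O)cc4C)cs3)CC2)nc1` differs from compound 2 by methyl in place of fluoro on an aromatic carbon. Among the compounds with values here, no step between measured compounds is available here, so no step beyond the scatter is expected in this assay. Compound 3 is therefore expected to give 100000 nM in this assay, between 50000 nM and 300000 nM, a step of a number no higher from compound 2 to compound 3 (the limit leaves the size open).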

Compound 3, half-maximal inhibitory concentration: > 100000 nM
Compound 3 was reported as a limit; the forecaster's own chance of this, stated with the estimate: 85%; the middle value lies on the limit itself.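

Compound 2 and compound 3 each report only a limit in this assay, so no step between them can be read: the limit of > 100000 nM in this assay, at which 3 of the 3 values shown sit.

The compounds shown leave open whether methyl in place of fluoro on an aromatic carbon shifts the value at all in this assay.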